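Swapping trifluoromethyl for fluoro on a dichloroacetanilide biaryl

The source may report more compounds than this note shows. Statements on the series, on what has been measured and on what is new or still open speak of the compounds shown alone.

The measured compounds:
compound 1, `O=C(Nc1cccc(-c2ccccc2C(F)(F)F)c1)C(Cl)Cl`, 7500 nM
compound 2, `COc1ccc(-c2cc(NC(=O)C(Cl)Cl)cc(-c3ccc(OC)c(F)c3)c2)cc1F`, 1950 nM
compound 3, `COc1ccc(-c2cccc(NC(=O)C(Cl)Cl)c2)cc1`, 8530 nM

Three dichloroacetamides carrying an aryl group on the shared core were measured in a functional assay on A549 cells (Homo sapiens) for cytotoxicity, read by MTT assay, with a stated time of 68 h; a lower number here means a stronger inhibitor, a higher number a weaker inhibitor. Compound 1 stands second highest of the three numbers; its nearest neighbour is compound 3, with a number that lies within the usual scatter of such measurements, while compound 2 stands furthest away with a number that is lower by a margin beyond the scatter. No two of these compounds differ in only one place, so no single structural step can be read from the measured set alone.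

Compound 4, `O=C(Nc1cccc(-c2ccccc2F)c1)C(Cl)Cl`, is not yet measured. It differs from compound 1 in one place: fluoro in place of trifluoromethyl on an aromatic carbon. The change keeps the donors and acceptors unchanged and only shrinks the substituent on the outer ring. Among the compounds with values here, the measured set gives no step that isolates a change at this position, so the size of the step in this assay is an expectation only. The author expects the step from compound 1 to compound 4 to be small, near the scatter, if anything toward a slightly higher number, so a 1.2-fold higher number from compound 1 to compound 4 (0.08 log units; within the scatter). For compound 4 the estimate is 9000 nM, with a range from 4000 nM to 20000 nM.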

Compound 4, half-maximal inhibitory concentration: 13200 nM
Compound 4: middle estimate off by 1.5-fold (0.17 log units), on the low side; the range from low to high includes it.
By their numbers in this assay, from the lowest: compound 2; then compounds 1, 3 and 4 (each within the scatter of the next).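

Within the data shown here, this pair gives the first step in the set that isolates a single place: in this assay, fluoro in place of trifluoromethyl on an aromatic carbon, ortho to a large group, gives a 1.8-fold higher number from compound 1 to compound 4 (0.25 log units; within the scatter) and so stays inside the usual scatter of repeated measurements. The substituent at this place therefore goes from 4 heavy atoms to 1, with no hydrogen-bond donors or acceptors on either side, and the assay cannot separate the two compounds; for this one pair, the choice between these two groups leaves the reading unresolved rather than marking a clear gain or loss. Nothing measured here bears on why the step came out this way.

Among these compounds, whether the same place would tolerate a group of another kind, such as an amine, a hydroxyl, a carboxylic acid or a longer alkyl chain, or a plain hydrogen, stays open, since fluoro and trifluoromethyl are the only two groups compared there. Among the compounds shown here, compound 2 and compound 3 each differ from compound 1 and compound 4 in more than one place, and from each other as well, so no step involving either of them can be read.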